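Swapping the aryl group on a hydrazone: cytotoxicity outlook

The source may report more compounds than this note shows. Statements on the series, on what has been measured and on what is new or still open speak of the compounds shown alone.

Of the compounds shown here, three sharing one core have been tested in an ADME assay on NIH3T3 cells (Mus musculus) for cytotoxicity, read by MTT assay, with a stated time of 24 h; on this read-out lower numbers stand for stronger inhibition and higher numbers for weaker inhibition. Compound 1 `O=C(CSc1nnc(-c2ccncc2)o1)N/N=C/c1cccc(C(F)(F)F)c1` gives 169000 nM in this assay. Compound 2 `O=C(CSc1nnc(-c2ccncc2)o1)N/N=C/c1ccccc1F` gives 142000 nM in this assay. Compound 3 `O=C(CSc1nnc(-c2ccncc2)o1)N/N=C/c1cc(Br)cc(Br)c1O` gives 190000 nM in this assay. Within the data shown here, all three numbers sit within the usual scatter of one another, so compound 2 cannot be set apart from compound 1 or compound 3 on these data; the one single-point step recorded, a 1.3-fold higher number from compound 2 to compound 3 (0.13 log units; within the scatter), confirms that exchanging the aryl group on the carbon double-bonded to nitrogen left the read-out essentially unchanged.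

Compound 4 `COc1cc(/C=N/NC(=O)CSc2nnc(-c3ccncc3)o2)ccc1O` has not yet been measured in this assay. It differs from compound 2 in one place: 4-hydroxy-3-methoxyphenyl in place of 2-fluorophenyl on a carbon with a double bond to nitrogen. Among the measured compounds shown here, the only measured step that bears on this change is the one from compound 2 to compound 3, which also exchanged the aryl group at that same carbon and stayed within the scatter. With nothing else to go on, the expected step for this assay is none beyond the scatter, that is a 1.1-fold higher number from compound 2 to compound 4 (0.05 log units; within the scatter). Compound 4 is therefore estimated at 160000 nM in this assay, with a plausible range from 80000 nM to 320000 nM.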

Compound 4, half-maximal inhibitory concentration: 148000 nM
The estimate for compound 4 lay 1.1-fold (0.03 log units) above the measured number; measured number inside the range.
By their numbers in this assay, from the lowest: compounds 2, 4, 1 and 3 (each within the scatter of the next).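

Among these compounds, compound 4 is the first compound here whose aryl group carries no halogen, whereas compounds 1, 2 and 3 each hold fluorine or bromine. Removing the halogen and adding the hydroxy and methoxy groups of 4-hydroxy-3-methoxyphenyl still leaves the read-out in this assay unchanged within the scatter: the exchange for 2-fluorophenyl gives a 1.0-fold higher number from compound 2 to compound 4 (0.02 log units; within the scatter) on the carbon with a double bond to nitrogen, and the exchange for 3,5-dibromo-2-hydroxyphenyl gives a 1.3-fold lower number from compound 3 to compound 4 (0.11 log units; within the scatter) at the same place. This position therefore accepts an aryl group with a hydrogen-bond donor and hydrogen-bond acceptors, which 2-fluorophenyl lacks, without a change that these data can separate from the scatter, and nothing measured here explains this result.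

From the compounds shown here alone, all four compounds still keep a six-membered aromatic ring of carbon only at this position, so it remains open whether an amine or a carboxylic acid on that ring, or a longer chain in its place, would move the number. The compounds shown also vary only this one position, leaving open how changes elsewhere in the shared core would affect the read-out.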